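Swapping Chloro for Nitro on the Aniline Ring

The compounds below may be only part of what the source reports. "The series", "measured", "known", "first", "only" and "open" are said of these compounds alone.

Compound 1, `CCOC(=O)C1=C(C)NC(=S)NC1c1cn(C(=O)CNc2ccccc2Cl)c2ccccc12`, gives 3.44 in a physicochemical assay for lipophilicity; a lower number here means a more polar compound, a higher number a more lipophilic compound.
Compound 2, `CCOC(=O)C1=C(C)NC(=S)NC1c1cn(C(=O)CNc2ccccc2[N+](=O)[O-])c2ccccc12`, gives 2.88 in this assay.
Compound 3, `CCOC(=O)C1=C(C)NC(=S)NC1c1cn(C(=O)CNc2ccc(Cl)cc2)c2ccccc12`, gives 3.44 in this assay.

Compound 4, `CCOC(=O)C1=C(C)NC(=S)NC1c1cn(C(=O)CNc2ccc([N+](=O)[O-])cc2)c2ccccc12`, has not yet been measured in this assay. It comes from compound 3 by nitro in place of chloro on an aromatic carbon. The same kind of change has been made once before: compound 2 comes from compound 1 by nitro in place of chloro on an aromatic carbon, and that step gave a number 0.56 log units lower from compound 1 to compound 2 (beyond the scatter). The two settings are not identical, though: in compound 1 the group sits ortho to a large group, whereas in compound 3 it sits para to a large group, so this is the same kind of change rather than the same one. The two cores differ by 4-chlorophenyl in place of 2-chlorophenyl on an amine nitrogen, a rearrangement that gave no change at the digits printed from compound 1 to compound 3 (within the scatter). Going by the values given here, with only that single earlier example to rest on, the step from compound 3 to compound 4 is expected to be a number 0.56 log units lower from compound 3 to compound 4 (beyond the scatter), in line with what compound 1 and compound 2 showed. Compound 4 is therefore estimated at 2.88, with a plausible range from 2.5 to 3.3.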

Compound 4, partition coefficient: 2.88
Beside the measured number, compound 4's estimate shows no gap at the digits printed; low and high end bracket the measured number.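

In this assay the swap of chloro for nitro gives a number 0.56 log units lower from compound 3 to compound 4 (beyond the scatter) on the second core and matched a number 0.56 log units lower from compound 1 to compound 2 (beyond the scatter) on the first, so in these two pairs the step carried over at full size. The other two steps agree with this: moving the nitro group from 2-nitrophenyl to 4-nitrophenyl gives no change at the digits printed from compound 2 to compound 4 (within the scatter) and the change from 2-chlorophenyl to 4-nitrophenyl gives a number 0.56 log units lower from compound 1 to compound 4 (beyond the scatter) so the same drop appears with either placement. Still, two pairs that differ only in where the group sits on one ring do not show that the step would hold on a more different core, and nothing measured here tells what lies behind the shift.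

The compounds shown hold only chloro and nitro on this ring, at these two places. From the compounds shown here alone, how a methoxy group, an amine or a carboxylic acid would behave there, and whether its step would also carry from one placement to the other, stays open.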